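The source may report more compounds than this note shows. Statements on the series, on what has been measured and on what is new or still open speak of the compounds shown alone.

In a functional assay on KG-1 cells (Homo sapiens) for cytotoxicity, read by luminescence and CellTiter-Glo, with a stated time of 3 days (a higher number here means a weaker inhibitor, a lower number a stronger inhibitor), compound 1 `O=C(Nc1cc(C(F)(F)F)cc(C(F)(F)F)c1)c1ccc(Br)cc1O` gives 830 nM and compound 2 `O=C(Nc1cc(C(F)(F)F)cc(C(F)(F)F)c1)c1cc(F)ccc1O` gives 470 nM. These two values lie within the usual scatter of each other, so compound 2 does not stand apart from compound 1 on the numbers available. The next structure, compound 3 `O=C(Nc1cc(C(F)(F)F)cc(C(F)(F)F)c1)c1ccc(Cl)cc1O`, carries 4-chloro-2-hydroxyphenyl in place of the 5-fluoro-2-hydroxyphenyl of compound 2 on a carbonyl carbon: 4-chloro-2-hydroxyphenyl in place of 5-fluoro-2-hydroxyphenyl on a carbonyl carbon. Within the data shown here, the one measured step that bears on this change is a 1.8-fold lower number from compound 1 to compound 2 (0.25 log units; within the scatter), where 5-fluoro-2-hydroxyphenyl took the place of 4-bromo-2-hydroxyphenyl. That step is small, and no other measurement tests an exchange on this group. No step beyond the scatter is therefore expected in this assay, and the estimated change is a 1.4-fold higher number from compound 2 to compound 3 (0.14 log units; within the scatter). The expected value for compound 3 is 650 nM, with an estimated range of 300 nM to 1400 nM.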

Compound 3, half-maximal inhibitory concentration: 620 nM
Beside the measured number, compound 3's estimate is 1.0-fold (0.02 log units) above it, and the stated range covers the measured number.
By their numbers in this assay, from the lowest: compounds 2, 3 and 1 (each within the scatter of the next).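

In this assay, among these compounds, compound 3 supplies the first exchange of one halogen for another with the ring place unchanged: chloro in place of bromo on an aromatic carbon gives a 1.3-fold lower number from compound 1 to compound 3 (0.13 log units; within the scatter) and does not separate the two compounds. The other new step, a 1.3-fold higher number from compound 2 to compound 3 (0.12 log units; within the scatter), also stays within the scatter, so 4-chloro-2-hydroxyphenyl, 4-bromo-2-hydroxyphenyl and 5-fluoro-2-hydroxyphenyl on the carbonyl carbon cannot be told apart by these numbers. No measurement is available that would account for this close grouping.

The three compounds leave open whether a group other than a halogen, such as an amine, a methoxy group or a carboxylic acid, would shift the number from this ring. They also leave open what would happen if the hydroxyl group or the trifluoromethyl groups of the shared core were replaced.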